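This account rests on a few compounds, and the source may have more. Where it says the series, first, only, none or still open, it means among the compounds named here.

Measured so far in an ADME assay on MCF-10A cells (Homo sapiens) for inhibition, with a stated time of 48 h; on this read-out higher numbers stand for weaker inhibition and lower numbers for stronger inhibition:
compound 1 `O=C(Nc1ccc(Cl)cc1)N1CCC[C@H]1c1nc(-c2ccccc2)no1`: > 50000 nM
compound 2 `O=C(Nc1ccc(Br)cc1)N1CCC[C@H]1c1nc(-c2ccccc2)no1`: > 50000 nM

In this assay compound 2 stands at > 50000 nM, which is a limit of the assay and not a number. Within the data shown here, its true position is therefore unknown, and the one other value is also a limit.

Compound 3 `O=C(Nc1ccc(I)cc1)N1CCC[C@H]1c1nc(-c2ccccc2)no1` has iodo in place of bromo on an aromatic carbon, para to a large group: iodo in place of bromo on an aromatic carbon. Among the measured compounds shown here, the only measured step that bears on this change is a step that the two limits leave unreadable from compound 1 to compound 2, where bromo replaces chloro on an aromatic carbon. It offers no size to carry over because of the limit of > 50000 nM in this assay, at which 2 of the 2 values shown sit. No defined shift in either direction is therefore expected, and compound 3 is expected to stay at the limit. The expected step is a number no higher from compound 2 to compound 3 (the limit leaves the size open). The estimate for compound 3 is 50000 nM, with an expected range of 25000 nM to 80000 nM.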

Compound 3, half-maximal inhibitory concentration: > 50000 nM
Compound 3: a limit, no number; the forecaster's own chance of this, stated with the estimate: 85%; the middle value lies on the limit itself.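

No step among compound 1, compound 2 and compound 3 can be read, as all three values are limits and not numbers: the limit of > 50000 nM in this assay, at which 3 of the 3 values shown sit.

The compounds shown leave open the true inhibition values and whether chloro, bromo and iodo differ at all.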